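The compounds below may be only part of what the source reports. "The series", "measured", "known", "first", "only" and "open" are said of these compounds alone.

Cytotoxicity toward cultured human liver cells was measured in an ADME assay on Huh-7 cells (Homo sapiens) for cytotoxicity; a lower number here means that less compound is tolerated, a higher number that more compound is tolerated. Compound 1 `O=C(NC(=S)n1ccc2c(OCCCCCOc3ccc(Cl)cc3)cccc21)c1ccccc1` gives 29500 nM in this assay. Compound 3 `COc1ccc(C(=O)NC(=S)N2CCc3c(OCCCCCOc4ccc(Cl)cc4)cccc32)cc1` gives 34400 nM in this assay. These two values lie within the usual scatter of repeated measurements, so neither compound can be said to be tolerated better than the other. Compound 2 `O=C(NC(=S)N1CCc2c(OCc3ccccc3)cccc21)c1ccccc1` reaches only (the limit of > 50000 nM in this assay, at which 1 of the 3 values shown sits); this is a limit of the assay and not a measured number. In this assay compound 2 is therefore recorded as > 50000 nM, a limit rather than a value.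

Compound 4 `S=C(NC(=S)N1CCc2c(OCCCCCOc3ccc(Cl)cc3)cccc21)Oc1ccccc1` has not yet been measured. It differs from compound 3 in a single place: a group of 9 heavy atoms (7 carbon, 1 oxygen, 1 sulfur; one six-membered aromatic ring of carbon only) in place of a group of 10 heavy atoms (8 carbon, 2 oxygen; one six-membered aromatic ring of carbon only), on an amide-type nitrogen. Among the measured compounds shown here, no pair of measured compounds differs in exactly this way, so there is no measured step to lean on. The two numbers that do exist, from compound 1 and compound 3, sit close together, and nothing in the data points to a shift beyond the scatter for this change. The step is expected to be a 1.0-fold lower number from compound 3 to compound 4 (0.01 log units; within the scatter), that is, no change beyond the usual scatter. Compound 4 is expected to give about 34000 nM in this assay, within a range from 15000 nM to 50000 nM.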

Compound 4, half-maximal cytotoxic concentration: > 50000 nM
Compound 4: no number, only a limit; the forecaster's own chance of this, stated with the estimate: 40%; at least 1.4-fold (0.16 log units) between middle value and limit.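

Among the compounds shown here, this is the first step measured at this position, the amide-type nitrogen whose other neighbour is the thiocarbonyl carbon, and in this assay the swap of the (4-methoxyphenyl)carbonyl group for the sulfur-bearing group gives an at least 1.4-fold higher number from compound 3 to compound 4 (0.16 log units; that floor lies within the scatter). The floor of that step lies within the scatter, so the data do not establish a real gain in tolerance, but they do show no loss of tolerance with this change, even with the long chain ending in a chlorinated ring kept in place. The result for compound 4 is a limit and not a number, and it joins compound 2 there, although the two compounds differ in more than one place and cannot be compared directly: the limit of > 50000 nM in this assay, at which 2 of the 4 values shown sit.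

The compounds shown do not separate the effect of bringing in sulfur from that of losing the methoxy group, and they leave unknown how far the true value of compound 4 lies from its limit. From the compounds shown here alone, how the read-out would respond to an amine or a carboxylic acid on the aromatic ring of this group, or to a longer chain in its place, also remains open.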